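The compounds below may be only part of what the source reports. "The series", "measured", "known", "first", "only" and "open" are said of these compounds alone.

In a functional assay on MCF7 cells (Homo sapiens) for inhibition, read by sulforhodamine B assay, with a stated time of 48 h (on this read-out higher numbers stand for weaker inhibition of growth and lower numbers for stronger inhibition of growth), three compounds have been measured:

compound 1 `N#Cc1c(-c2nnc(O)c3nn(-c4ccccc4)cc23)nn(-c2ccccc2)c1-c1ccccc1`: > 100000 nM (a limit)
compound 2 `N#Cc1c(-c2nnc(O)c3nn(-c4ccc(Cl)cc4)cc23)nn(-c2ccccc2)c1-c1ccccc1`: > 100000 nM (a limit)
compound 3 `N#Cc1c(-c2nnc(-c3nn(-c4ccccc4)c(-c4ccccc4)c3C#N)c3nn(-c4ccccc4)cc23)nn(-c2ccccc2)c1-c1ccccc1`: 17800 nM

Compound 2 gives > 100000 nM and this is a limit, not a number. Compound 1 also gives only a limit, so both sit at the limit of > 100000 nM in this assay, at which 2 of the 3 values shown sit, and neither has an exact position. Going by the values given here, the one measured step is a step that the two limits leave unreadable from compound 1 to compound 2 and it offers no size to carry over. It also concerns chloro, not the group that changes here.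

Compound 4 `N#Cc1c(-c2nnc(-c3ccccc3)c3nn(-c4ccc(Cl)cc4)cc23)nn(-c2ccccc2)c1-c1ccccc1` differs from compound 2 by phenyl in place of hydroxy on an aromatic carbon and has not yet been measured. Among the compounds with values here, the only guide is compound 3, which has a larger aromatic group instead of hydroxy at that place and gives 17800 nM as a real number. Compound 3 has no chloro, however, and this single case sets no firm size. In this assay a move towards stronger inhibition of growth is therefore expected, though the starting point is only a limit. The estimated change is an at least 3.3-fold lower number from compound 2 to compound 4 (0.52 log units; beyond the scatter) with a wide margin. Compound 4 is expected at 30000 nM within an estimated range from 8000 nM to 100000 nM and may yet return only a limit.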

Compound 4, concentration for 50% growth inhibition: 43800 nM
The estimate for compound 4 lay 1.5-fold (0.16 log units) below the measured number; the range from low to high includes it.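

In this assay, going by these compounds alone, phenyl in place of hydroxy on an aromatic carbon of the six-membered aromatic ring with 2 nitrogen gives an at least 2.2-fold lower number from compound 2 to compound 4 (0.35 log units; beyond the scatter), the first step at this place with a readable direction. Compound 4 keeps the chloro of compound 2, so the earlier picture of the hydroxy compounds, which gave only limits, now gains a real number from a single phenyl ring at this place with the chloro present. The size of the step is only a lower bound, as the value of compound 2 is a limit and not a number: the limit of > 100000 nM in this assay, at which 2 of the 4 values shown sit.

The compounds shown do not separate the effect of phenyl entering from that of hydroxy leaving, and an amine, a methoxy group or a short alkyl chain at this place would be needed to tell the two apart. It also remains open whether the chloro matters once phenyl is present, as no pair shown differs in the chloro alone with a readable result.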